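A few compounds are considered here, and "the series" means these few. Any claim that something is new, unique, unknown or untested is made for them only; others in the source may bear on it.

Compound 1 `CS(=O)(=O)Nc1c(O)ccc2c1CCCC2c1c[nH]cn1` gives 104% in a functional assay on Urethra with Alpha-1A adrenergic receptor (Oryctolagus cuniculus) as the target; a higher number here means a larger maximal response, a lower number a smaller maximal response.
Compound 2 `CC(=O)Nc1cccc2c1CCCC2c1c[nH]cn1` gives 70% in this assay.
Compound 3 `CS(=O)(=O)Nc1ccc(F)c2c1CCCC2c1c[nH]cn1` gives 64% in this assay.

Among these three numbers compound 2 stands second highest. Its nearest neighbour is compound 3, whose value lies within the scatter of it, so the two cannot be ordered; compound 1 lies beyond the scatter above compound 2. Compound 4 `CC(C)S(=O)(=O)Nc1cccc2c1CCCC2c1c[nH]cn1` has not yet been measured in this assay. It differs from compound 2 in one place: isopropylsulfonyl in place of acetyl on a nitrogen on an aromatic ring. Within the data shown here, no measured pair shows this change on its own, so no step can be read off. A small step, not beyond the scatter, is expected, leaning slightly upward. Compound 4 is expected to give 75% in this assay, with a range from 50% to 100%. This estimate means an expected step of a number 5 percentage points higher from compound 2 to compound 4 (within the scatter).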

Compound 4, largest response reached (reported as efficacy), in percent of the reference or control that the assay uses: 74%
The estimate for compound 4 lay 1 percentage points above the measured number; low and high end bracket the measured number.
By their numbers in this assay, from the lowest: compounds 3, 2 and 4 (each within the scatter of the next); then compound 1.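

Replacing acetyl with isopropylsulfonyl on the nitrogen gives a number 4 percentage points higher from compound 2 to compound 4 (within the scatter) in this assay. This position therefore accepts a group of 6 heavy atoms in place of one of 3, with a sulfonyl in place of a carbonyl, and the maximal response cannot be told apart from that of the acetyl compound. Nothing measured here explains this result. From the compounds shown here alone, it remains open whether the response would also hold with a phenyl group or a dimethylamino group in place of the isopropyl on the sulfonyl.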